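The source may report more compounds than this note shows. Statements on the series, on what has been measured and on what is new or still open speak of the compounds shown alone.

Series notes. Compound 1 `Cn1cncc1C(OCc1ccc(C#N)nc1-c1cccc(Cl)c1)c1ccc(C#N)cc1` is measured in an assay on isolated protein (Bos taurus) for inhibition of geranylgeranyl transferase type-1 subunit beta (Homo sapiens) (on this read-out higher numbers stand for weaker inhibition and lower numbers for stronger inhibition), at 1700 nM. Among the three measured compounds this places compound 1 second highest: compound 2 `Cn1cncc1C(OCc1ccc(C#N)cc1-c1ccc(F)c(Cl)c1)c1ccc(C#N)nc1` gives 8600 nM in this assay, a higher number beyond the scatter, whereas compound 3 `Cn1cncc1C(OCc1ccc(C#N)cc1)c1ccc(C#N)c(-c2cccc3cccnc23)c1` gives 103 nM in this assay, a lower number beyond the scatter. No two of these differ in a single place, so each shows only its own value. Compound 4 `Cn1cncc1C(OCc1ccc(C#N)nc1-c1cc(Cl)cc(Cl)c1)c1ccc(C#N)cc1` is not yet measured; it differs from compound 1 by chloro in place of hydrogen on an aromatic carbon, the 3-chlorophenyl becoming 3,5-dichlorophenyl. Nothing measured here tracks such a change, so the step of a 1.3-fold lower number from compound 1 to compound 4 (0.12 log units; within the scatter) is expected to be modest and possibly none beyond the scatter. For compound 4 the expected value in this assay is 1300 nM, within 450 nM to 4000 nM.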

Compound 4, half-maximal inhibitory concentration: 1400 nM
The estimate for compound 4 lay 1.1-fold (0.03 log units) below the measured number; the measured number falls inside the stated range.
By their numbers in this assay, from the lowest: compound 3; then compounds 4 and 1 (each within the scatter of the next); then compound 2.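

In this assay, for the compounds shown here, the change from 3-chlorophenyl to 3,5-dichlorophenyl gives a 1.2-fold lower number from compound 1 to compound 4 (0.08 log units; within the scatter) and so stays inside the scatter, the first single-place comparison. This position therefore accepts a second chloro on the aromatic carbon without a shift that can be told from repeat variation. No measurement shown bears on why this is so. Still open, going by these compounds, is whether a methoxy group, an amine or a carboxylic acid at this place would move the number, and whether chloro behaves alike on the cores of compound 2 and compound 3.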